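Fluoro in place of amino on compound 1

The compounds below may be only part of what the source reports. "The series", "measured", "known", "first", "only" and "open" are said of these compounds alone.

In a functional assay on HCT-116 cells (Homo sapiens) for inhibition, read by MTT assay, with a stated time of 48 h (on this read-out higher numbers stand for weaker inhibition and lower numbers for stronger inhibition), compound 1 (`C/C=C/C(=O)N(Cc1ccc(OC)c(N)c1)c1cc(OC)c(OC)c(OC)c1`) gives 300 nM and compound 2 (`C/C=C/C=C/C(=O)N(Cc1ccc(OC)c(O)c1)c1cc(OC)c(OC)c(OC)c1`) gives 180 nM on the same read-out. These two values lie within the usual scatter of each other, so compound 1 cannot be separated from compound 2 on these numbers. Among the measured compounds shown here, no two measured compounds differ in one place only, which leaves no measured step to guide a prediction.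

Compound 3 (`C/C=C/C(=O)N(Cc1ccc(OC)c(F)c1)c1cc(OC)c(OC)c(OC)c1`) has not yet been measured. It keeps the core of compound 1 but carries fluoro in place of amino on an aromatic carbon, ortho to a methoxy group (fluoro in place of amino on an aromatic carbon). The same difference can be read as 3-amino-4-methoxyphenyl to 3-fluoro-4-methoxyphenyl.

For the measured compounds named here, with no measured precedent for this change, the expectation is a modest move towards a higher number in this assay and so somewhat weaker inhibition, although a result within the scatter would be no surprise. The expected size is a 1.8-fold higher number from compound 1 to compound 3 (0.26 log units; within the scatter) (an estimate with wide uncertainty). For compound 3 the estimated value is 550 nM (expected range 170 nM to 2000 nM).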

Compound 3, half-maximal inhibitory concentration: 1160 nM
The estimate for compound 3 lay 2.1-fold (0.32 log units) below the measured number, and the stated range covers the measured number.
By their numbers in this assay, from the lowest: compounds 2 and 1 (each within the scatter of the next); then compound 3.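

In this assay, among the compounds shown here, fluoro in place of amino on the aromatic carbon ortho to a methoxy group gives a 3.9-fold higher number from compound 1 to compound 3 (0.59 log units; beyond the scatter), the first measured single-place step here and one that lies beyond the scatter. This shows that the group at this position affects the read-out and that, on the core of compound 1, the change from 3-amino-4-methoxyphenyl to 3-fluoro-4-methoxyphenyl weakens inhibition. The change also replaces a group counted with one hydrogen-bond donor and one acceptor by a group counted with neither, but no measurement here ties the step to that difference or to any other cause.

The compounds shown leave open whether the step reflects the loss of amino or the arrival of fluoro, a question that a hydrogen, a chloro group or a methylamino group at the same position could help to address. They also leave open whether the exchange of amino for fluoro would produce a step of similar size on the longer chain carried by compound 2.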